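This account rests on a few compounds, and the source may have more. Where it says the series, first, only, none or still open, it means among the compounds named here.

Compound 1 `CC(C)c1n[nH]c2c(NCc3ccc(-c4ccccn4)cc3)nc(S(C)(=O)=O)nc12` gives 460 nM in a functional assay on MCF7 cells (Homo sapiens) for cytotoxicity, read by fluorescence, with a stated time of 72 h (on this read-out lower numbers stand for stronger inhibition and higher numbers for weaker inhibition), the highest of the two numbers seen so far. Compound 2 `CC(C)c1n[nH]c2c(NCc3ccc(-c4ccccn4)cc3)nc(NCCN)nc12` gives 62 nM in this assay. Going by the values given here, the one recorded step is a 7.4-fold lower number from compound 1 to compound 2 (0.87 log units; beyond the scatter), in which (2-aminoethyl)amino replaced methylsulfonyl. Compound 3 `CC(C)c1n[nH]c2c(NCc3ccc(-c4ccccn4)cc3)nc(N3CCNCC3)nc12` carries a related change: piperazin-1-yl in place of methylsulfonyl on an aromatic carbon. That single step from methylsulfonyl to (2-aminoethyl)amino is the only one that bears on this change; it was modest and beyond the scatter. Compound 3 is therefore expected to show a lowering of similar size, so that a 4.6-fold lower number from compound 1 to compound 3 (0.66 log units; beyond the scatter). Compound 3 is estimated at 100 nM, in a range from 35 nM to 300 nM.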

Compound 3, half-maximal inhibitory concentration: 21 nM
Compound 3: middle estimate off by 4.8-fold (0.68 log units), on the high side; the measured number lies below the stated range.
By their numbers in this assay, from the lowest: compound 3; then compound 2; then compound 1.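

In this assay, replacing methylsulfonyl on this aromatic carbon goes further when the incoming amine is closed into a ring, as piperazin-1-yl shows (a 22-fold lower number from compound 1 to compound 3 (1.34 log units; beyond the scatter)). The ring and the open chain can also be told apart at this position, since piperazin-1-yl differs from (2-aminoethyl)amino (a 3.0-fold lower number from compound 2 to compound 3 (0.47 log units; beyond the scatter)). Nothing measured here explains that difference. The compounds shown leave open how morpholin-4-yl, 4-methylpiperazin-1-yl or a longer aminoalkyl chain would compare at this carbon.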